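Replacing phenyl with furan-3-yl in compound 3

A few compounds are considered here, and "the series" means these few. Any claim that something is new, unique, unknown or untested is made for them only; others in the source may bear on it.

In a functional assay (blood) for inhibition, with Homo sapiens as the target (a higher number here means a weaker inhibitor, a lower number a stronger inhibitor), compound 1 `CC(O)c1cc(-c2ccccc2)c2ccc(OCc3cccc(C4(O)CCOCC4)c3)cc2c1` gives 675 nM. Compound 2 `COC(C)c1cc(-c2ccccc2)c2ccc(OCc3cccc(C4(O)CCOCC4)c3)cc2c1` reads > 1000 nM, which is a limit of the assay and not a number. Compound 3 `N#Cc1cc(-c2ccccc2)c2ccc(OCc3cccc(C4(O)CCOCC4)c3)cc2c1` gives 100 nM, the lowest number of the three. The data show a 6.8-fold lower number from compound 1 to compound 3 (0.83 log units; beyond the scatter), and also an at least 10-fold lower number from compound 2 to compound 3 (1.00 log units; beyond the scatter).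

Compound 4 `N#Cc1cc(-c2ccoc2)c2ccc(OCc3cccc(C4(O)CCOCC4)c3)cc2c1` keeps the cyano group and carries furan-3-yl in place of phenyl on an aromatic carbon. Every measured step exchanges the group where compound 3 has its cyano, while the phenyl stays unchanged throughout. These steps therefore give no direct size for the new change, and no shift beyond the scatter is expected in this assay. Compound 3 at 100 nM holds the lowest number, so the expectation leans slightly towards a higher one. The expected step is a 1.4-fold higher number from compound 3 to compound 4 (0.15 log units; within the scatter). The estimate for compound 4 is 140 nM, with an expected range from 50 nM to 400 nM.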

Compound 4, half-maximal inhibitory concentration: 10 nM
Estimate against measurement, compound 4: 14-fold (1.15 log units) above, outside the stated range (below it).
By their numbers in this assay, from the lowest: compound 4; then compound 3; then compound 1. At a limit, above all of these: compound 2.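

In this assay, among these compounds, the aromatic group ortho to a fused ring and meta to the cyano group, unchanged in the earlier compounds, turns out to matter: with furan-3-yl in place of phenyl, the data show a 10-fold lower number from compound 3 to compound 4 (1.00 log units; beyond the scatter). The earlier steps had shown only that the group at the cyano position moves the number, as in a 6.8-fold lower number from compound 1 to compound 3 (0.83 log units; beyond the scatter), so a second place on the shared core now also shifts it beyond the scatter. Nothing given here accounts for this gain, and this single pair does not separate the smaller ring from the added ring oxygen.

Going by these compounds, it remains open whether thiophene-3-yl or pyridin-3-yl at this position would behave like furan-3-yl. On these data alone, it is also open whether furan-3-yl would give a similar step with 1-hydroxyethyl in place of the cyano group.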